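This account rests on a few compounds, and the source may have more. Where it says the series, first, only, none or still open, it means among the compounds named here.

Compound 1 `NCCNc1cc2c(cc1F)c(=O)c(C(=O)O)cn2Cc1ccc(-c2ccccc2)cc1` gives 72800 nM in an assay on isolated protein for inhibition of DNA topoisomerase 1 (Homo sapiens), with a stated time of 15 min (a lower number here means a stronger inhibitor, a higher number a weaker inhibitor), the lowest of the two numbers at hand. Compound 2 `NC[C@@H]1CCN(c2cc3c(cc2F)c(=O)c(C(=O)O)cn3Cc2ccc(-n3cccn3)cc2)C1` gives 91600 nM in this assay, a value within the scatter of compound 1, so the two numbers tell no order between them. Compound 3 `O=C(O)c1cn(Cc2ccc(-c3ccccc3)cc2)c2cc(N3C[C@H]4CCNC[C@H]4C3)c(F)cc2c1=O` awaits measurement in this assay. It differs from compound 1 by a group of 9 heavy atoms (7 carbon, 2 nitrogen; one five-membered non-aromatic ring with 1 hetero atom, one six-membered non-aromatic ring with 1 hetero atom) in place of a group of 4 heavy atoms (2 carbon, 2 nitrogen; no ring), on an aromatic carbon. For the measured compounds named here, no measured pair shows a step of this kind, so only the weak numbers of compound 1 and compound 2 guide the expectation. Compound 3 is expected to give 50000 nM, between 15000 nM and 150000 nM. The estimated step of a 1.5-fold lower number from compound 1 to compound 3 (0.16 log units; within the scatter) is expected to stay within the scatter.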

Compound 3, half-maximal inhibitory concentration: 61000 nM
The estimate for compound 3 lay 1.2-fold (0.09 log units) below the measured number; the measured number falls inside the stated range.
By their numbers in this assay, from the lowest: compounds 3, 1 and 2 (each within the scatter of the next).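

On the aromatic carbon ortho to a fluoro group, the group with a five-membered and a six-membered non-aromatic ring stands in place of (2-aminoethyl)amino, with a 1.2-fold lower number from compound 1 to compound 3 (0.08 log units; within the scatter) in this assay. A much larger group bearing two rings therefore leaves the number in the same weak range as the open chain. Nothing at hand explains this result. On these data alone, it remains open whether any group at this carbon can move the number beyond the scatter. A piperazine ring or a longer amine chain there would test this.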